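A few compounds are considered here, and "the series" means these few. Any claim that something is new, unique, unknown or untested is made for them only; others in the source may bear on it.

Values so far in a functional assay on NMC-797 cells (Homo sapiens) for antiproliferative activity, with a stated time of 48 h; a lower number here means a stronger inhibitor, a higher number a weaker inhibitor:
Compound 1 `O=C1C=C[C@]2(C[C@@H](c3cccc([N+](=O)[O-])c3)O[C@@H](c3ccccc3)O2)O1` gives 160 nM 
Compound 2 `O=C1C=C[C@]2(C[C@@H](c3ccccc3)O[C@@H](c3cccc([N+](=O)[O-])c3)O2)O1` gives 120 nM 

Of these two compounds, compound 2 stands level with compound 1, since their values lie within the usual scatter of each other. Compound 3 `O=C1C=C[C@]2(C[C@@H](c3cccc([N+](=O)[O-])c3)O[C@@H](c3cccc([N+](=O)[O-])c3)O2)O1` has not yet been measured. It differs from compound 2 by nitro in place of hydrogen on an aromatic carbon, meta to a large group, so that a phenyl becomes a 3-nitrophenyl: nitro in place of hydrogen on an aromatic carbon 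

Within the data shown here, no measured pair shows this change on its own, so any forecast rests on little. Among the measured compounds shown here, the only guide is that compound 1 at 160 nM and compound 2 at 120 nM sit close together in this assay, each with a single nitro group, while compound 3 has two. On that basis, no step beyond the scatter is expected, in either direction, and the range has to stay wide. The expected change is a 1.1-fold lower number from compound 2 to compound 3 (0.04 log units; within the scatter), and this is only an estimate. For compound 3 the estimated value is 110 nM, with an expected range from 45 nM to 300 nM.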

Compound 3, half-maximal inhibitory concentration: 47 nM
Compound 3: the middle estimate sits 2.3-fold (0.37 log units) above what was measured, and the stated range covers the measured number.
By their numbers in this assay, from the lowest: compound 3; then compounds 2 and 1 (each within the scatter of the next).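

In this assay, the change from a phenyl to a 3-nitrophenyl gives a step beyond the scatter at either of the two phenyl groups of the shared core: a 2.6-fold lower number from compound 2 to compound 3 (0.41 log units; beyond the scatter) at one, and a 3.4-fold lower number from compound 1 to compound 3 (0.53 log units; beyond the scatter) at the other. The earlier compounds shown here each carried a single 3-nitrophenyl and differed in more than one place, so they could not show this change alone; these two modest steps show that a second nitro group lowers the number in this assay, whichever phenyl receives it. Nothing available here bears on what lies behind these steps.

The compounds shown carry only hydrogen or nitro at this position on the ring, so it remains open whether the lower number belongs to nitro itself or could also come with a nitrile, an amine or a carboxylic acid in the same place. On these data alone, it also remains open whether nitro would give similar steps at other positions of these rings, since every nitro group here stands in a 3-nitrophenyl.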